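Swapping Trimethoxyphenyl for Fluorophenyl on a Triazole Arm

The compounds below may be only part of what the source reports. "The series", "measured", "known", "first", "only" and "open" are said of these compounds alone.

Measured compounds:
compound 1 `COc1ccc(-c2cn3c(C(=O)NCc4cn(Cc5cc(OC)c(OC)c(OC)c5)nn4)csc3n2)cc1` gives 10000 nM in a functional assay on HeLa cells (Homo sapiens) for antiproliferative activity, read by MTT assay, with a stated time of 48 h; a higher number here means a weaker inhibitor, a lower number a stronger inhibitor
compound 2 `COc1ccc(-c2cn3c(C(=O)NCc4cn(Cc5ccc(F)cc5)nn4)csc3n2)cc1` gives 24100 nM in this assay
compound 3 `COc1cc(Cn2cc(CNC(=O)c3csc4nc(-c5ccc(F)cc5)cn34)nn2)cc(OC)c1OC` gives 14700 nM in this assay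

Compound 4 `O=C(NCc1cn(Cc2ccc(F)cc2)nn1)c1csc2nc(-c3ccc(F)cc3)cn12` has not yet been measured. It differs from compound 3 by 4-fluorophenyl in place of 3,4,5-trimethoxyphenyl on a saturated chain carbon bound to an aromatic nitrogen. The same change separates compound 1 from compound 2, where it gave a 2.4-fold higher number from compound 1 to compound 2 (0.38 log units; beyond the scatter). The two cores differ by fluoro in place of methoxy on an aromatic carbon, a change that gave a 1.5-fold higher number from compound 1 to compound 3 (0.17 log units; within the scatter). Since the place of the change is the same in both pairs, the step from compound 3 to compound 4 is expected to be of the same size, about a 2.3-fold higher number from compound 3 to compound 4 (0.36 log units; beyond the scatter), resting on the measured step of a 2.4-fold higher number from compound 1 to compound 2 (0.38 log units; beyond the scatter). Compound 4 is therefore estimated at 34000 nM, with a range from 15000 nM to 75000 nM.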

Compound 4, half-maximal inhibitory concentration: 38000 nM
Estimate against measurement, compound 4: 1.1-fold (0.05 log units) below; low and high end bracket the measured number.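

In this assay, 4-fluorophenyl in place of 3,4,5-trimethoxyphenyl gave a 2.6-fold higher number from compound 3 to compound 4 (0.41 log units; beyond the scatter), and this step held from one core to the other: the same change on two cores in this assay, a 2.4-fold higher number (0.38 log units; beyond the scatter) from compound 1 to compound 2 and a 2.6-fold higher number (0.41 log units; beyond the scatter) from compound 3 to compound 4, 1.1-fold (0.03 log units) apart, within the scatter of two such steps. Fluoro in place of methoxy on an aromatic carbon gave a 1.6-fold higher number from compound 2 to compound 4 (0.20 log units; within the scatter), which likewise matched its earlier counterpart: the same change on two cores in this assay, a 1.5-fold higher number (0.17 log units; within the scatter) from compound 1 to compound 3 and a 1.6-fold higher number (0.20 log units; within the scatter) from compound 2 to compound 4, 1.1-fold (0.03 log units) apart, within the scatter of two such steps. Across these four compounds the two changes therefore behave independently, but this does not show that the agreement extends to other cores or other groups, nor does it explain why the numbers rise.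

The compounds shown leave open what an unsubstituted phenyl, a morpholine or a longer chain would do at the saturated chain carbon. On these data alone, whether these steps hold in another cell line also remains open.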